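The compounds below may be only part of what the source reports. "The series", "measured", "known", "first", "only" and "open" are said of these compounds alone.

Compound 3 `COc1cc(C(=O)N2CCCC2(C)C)cc2nc(NCc3cccc(Cl)c3)oc12` gives 47 nM in an assay on isolated protein for inhibition of thyroid hormone receptor beta (Homo sapiens), read by fluorescence, with a stated time of 30 min; on this read-out lower numbers stand for stronger inhibition and higher numbers for weaker inhibition. Among the three measured compounds it stands second highest: compound 2 `CCCN(CC1CCOC1)C(=O)c1cc(C)c2oc(NCc3cccc(Cl)c3)nc2c1` gives 35 nM, a gap within the scatter, while compound 1 `CCCN(CC1CCOC1)C(=O)c1ccc2oc(NCc3cccc(Cl)c3)nc2c1` gives 214 nM, a gap beyond it. Compound 4 `COc1cc(C(=O)N2CC[C@H](O)[C@@H](C)C2)cc2nc(NCc3cccc(Cl)c3)oc12` differs from compound 3 in one place: 4-hydroxy-3-methylpiperidin-1-yl in place of 2,2-dimethylpyrrolidin-1-yl on a carbonyl carbon. For the measured compounds named here, the only measured step, a 6.1-fold lower number from compound 1 to compound 2 (0.79 log units; beyond the scatter), concerns a methyl on an aromatic carbon and does not bear on an exchange of the ring attached to the carbonyl, so no measured pair informs this change. The step to compound 4 is therefore expected to be about a 1.3-fold higher number from compound 3 to compound 4 (0.11 log units; within the scatter), within the scatter but with wide uncertainty. Compound 4 is estimated at 60 nM, with a range from 15 nM to 250 nM.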

Compound 4, half-maximal inhibitory concentration: 120 nM
Compound 4: middle estimate off by 2.0-fold (0.30 log units), on the low side; the range from low to high includes it.
By their numbers in this assay, from the lowest: compounds 2 and 3 (each within the scatter of the next); then compounds 4 and 1 (each within the scatter of the next).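

For the compounds shown here, the ring on the carbonyl carbon is not a silent exchange: 4-hydroxy-3-methylpiperidin-1-yl in place of 2,2-dimethylpyrrolidin-1-yl gives a 2.6-fold higher number from compound 3 to compound 4 (0.41 log units; beyond the scatter) and so shows that this position responds to what it carries, which the earlier compounds could not show. The entering group differs at once in ring size, hydrogen-bond donor and defined stereocentres. Nothing measured here explains the step. On these data alone, it remains open which of these differences carries the step, and how a plain piperidin-1-yl or a morpholin-4-yl would fare on the same carbonyl carbon.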